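Ester variation on the hydroxyethyl side chain: cytotoxicity notes

This account rests on a few compounds, and the source may have more. Where it says the series, first, only, none or still open, it means among the compounds named here.

Compound 3 `O=C(O)CCCC(=O)OCCc1c(-c2ccccc2Cl)c2cc(Cl)ccc2[nH]c1=O` gives 110000 nM in an ADME assay on HepG2 2.2.15 cells (Homo sapiens) for cytotoxicity (a lower number here means that less compound is tolerated, a higher number that more compound is tolerated), the highest of the two numbers in hand. Compound 1 `C=CCn1c(=O)c(CCO)c(-c2ccccc2Cl)c2cc(Cl)ccc21` gives 23000 nM in this assay. Compound 2 `O=c1c(CCO)c(-c2ccccc2Cl)c2cc(Cl)ccc2n1-c1c(F)cccc1F` reaches only a limit, > 2300000 nM, in this assay; this is the limit of > 2300000 nM in this assay, at which 1 of the 3 values shown sits. For the measured compounds named here, the single measured step, an at least 100-fold higher number from compound 1 to compound 2 (2.00 log units; beyond the scatter), concerns the substituent on the aromatic nitrogen and not the ester, so no measured step bears directly on the change to compound 4 `CC12CCC(C(=O)OCCc3c(-c4ccccc4Cl)c4cc(Cl)ccc4[nH]c3=O)(OC1=O)C2(C)C`, which is a group of 11 heavy atoms (9 carbon, 2 oxygen; one five-membered non-aromatic ring of carbon only, one five-membered non-aromatic ring with 1 hetero atom) in place of a group of 6 heavy atoms (4 carbon, 2 oxygen; no ring), on a carbonyl carbon. Going by the values given here, with no precedent at the carbonyl carbon, no change beyond the scatter is expected, and the step from compound 3 to compound 4 is estimated as a 1.6-fold lower number from compound 3 to compound 4 (0.20 log units; within the scatter). Compound 4 is expected near 70000 nM, with a range from 20000 nM to 250000 nM.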

Compound 4, half-maximal cytotoxic concentration: > 1800000 nM
Compound 4 ended at the assay's limit; the forecaster's own chance of this, stated with the estimate: 10%; middle value at least 25-fold (1.41 log units) from the limit.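

The carbonyl carbon of the ester is a place where a single change moves the number well beyond the scatter: an at least 16-fold higher number from compound 3 to compound 4 (1.21 log units; beyond the scatter) in this assay. For the compounds shown here, the only earlier step lay on the aromatic nitrogen, so this is the first measured sensitivity on the ester side. Compound 4 gives only a limit, > 1800000 nM, and the full size of the step stays unread: the limit of > 1800000 nM in this assay, at which 1 of the 4 values shown sits.

On these data alone, it remains open whether the loss of the carboxylic acid in 3-carboxypropyl or the entry of the two-ring group carries the step. A plain tert-butyl group on the same carbonyl carbon would separate the two.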